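This account rests on a few compounds, and the source may have more. Where it says the series, first, only, none or still open, it means among the compounds named here.

Measured so far:
compound 1 `CCN1CCN(c2cc(C)c3cc(NC(=O)c4cccc(C)c4)ccc3n2)CC1`: 13700 nM
compound 2 `Cc1cc(N2CCCC2)nc2ccc(NC(=O)c3ccc(Cl)c(Cl)c3)cc12`: 43400 nM
compound 3 `CCc1ccccc1C(=O)Nc1ccc2nc(N3CCN(CC)CC3)cc(C)c2c1`: 23900 nM

All three numbers come from a functional assay on SK-BR-3 cells (Homo sapiens) for antiproliferative activity, read by MTT assay, with a stated time of 72 h; on this read-out lower numbers stand for stronger inhibition and higher numbers for weaker inhibition. Compound 2 , at 43400 nM, cannot be told apart from compound 3 , at 23900 nM, but its number is higher than that of compound 1 , at 13700 nM, by more than the scatter.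

The next compound is compound 4 `Cc1cc(NCCN2CCN(C)CC2)nc2ccc(NC(=O)c3ccc(Cl)c(Cl)c3)cc12`. It replaces the pyrrolidin-1-yl of compound 2 with (2-(4-methylpiperazin-1-yl)ethyl)amino on an aromatic carbon next to the ring nitrogen: (2-(4-methylpiperazin-1-yl)ethyl)amino in place of pyrrolidin-1-yl on an aromatic carbon.

Within the data shown here, no measured step covers this change directly. The only one available is a 1.7-fold higher number from compound 1 to compound 3 (0.24 log units; within the scatter). It lies within the scatter and concerns the group on the carbonyl carbon, so it says little here. Some indirect help comes from compound 1 and compound 3 , which also carry a six-membered non-aromatic ring with 2 hetero atoms on that carbon. Their numbers are no higher than that of compound 2 , yet they also differ from it around the carbonyl, so this is weak evidence. A modest move towards lower numbers is therefore expected, with wide uncertainty, and the estimate is a 2.9-fold lower number from compound 2 to compound 4 (0.46 log units; beyond the scatter). For compound 4 the expected value is 15000 nM, with an estimated range of 4000 nM to 45000 nM.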

Compound 4, half-maximal inhibitory concentration: 2690 nM
The estimate for compound 4 lay 5.6-fold (0.75 log units) above the measured number; the measured number lies below the stated range.
By their numbers in this assay, from the lowest: compound 4; then compounds 1, 3 and 2 (each within the scatter of the next, the first and the last beyond it).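

In this assay, among these compounds, the group on the aromatic carbon next to the ring nitrogen turns out to matter a great deal: the change gives a 16-fold lower number from compound 2 to compound 4 (1.21 log units; beyond the scatter), whereas the only earlier step, made at the carbonyl, gave a 1.7-fold higher number from compound 1 to compound 3 (0.24 log units; within the scatter). This single swap alters several features at once, since (2-(4-methylpiperazin-1-yl)ethyl)amino brings a six-membered non-aromatic ring with 2 hetero atoms, 1 hydrogen-bond donor and 3 hydrogen-bond acceptors, where pyrrolidin-1-yl has a five-membered ring, 0 donors and 1 acceptor, so the step cannot be credited to any one of them. No measurement shown here explains why the number falls.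

Going by these compounds, it remains open which part of the new group carries the effect: a 4-methylpiperazin-1-yl ring attached directly to the aromatic carbon, or a 2-(dimethylamino)ethylamino chain with no ring, would help to separate the ring from the chain and its amine hydrogen. On these data alone, it is also open whether the same swap would give a step of similar size with 3-methylphenyl or 2-ethylphenyl on the carbonyl carbon in place of the dichlorophenyl ring of compound 4.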